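Fluoro for hydrogen on the benzyl group of compound 3

The source may report more compounds than this note shows. Statements on the series, on what has been measured and on what is new or still open speak of the compounds shown alone.

Measured so far:
compound 1 `Cn1cnc2c(Sc3ccccc3)ncnc21`: 0%
compound 2 `c1ccc(-[n+]2c[nH]c3ncncc32)cc1`: 0%
compound 3 `c1ccc(C[n+]2c[nH]c3ncncc32)cc1`: 9%

All three numbers come from an assay on isolated protein for inhibition of RAC-alpha serine/threonine-protein kinase (Homo sapiens), tested at 30 uM; on this read-out higher numbers stand for more inhibition at the one concentration tested (going by the name of the read-out) and lower numbers for less inhibition. Compound 3 has the highest of the three numbers, but its gap to compound 1 and its gap to compound 2 both lie within the usual scatter, so no order among the three can be read from these values; all three sit at or near the floor of the read-out.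

Compound 4 `Fc1ccc(C[n+]2c[nH]c3ncncc32)cc1` differs from compound 3 by fluoro in place of hydrogen on an aromatic carbon. Going by the values given here, no step between measured compounds is available to show what such a change does in this assay. Nothing in the three numbers points to a move beyond the scatter, so the step of a number 2 percentage points lower from compound 3 to compound 4 (within the scatter) is expected to be none beyond the scatter. Compound 4 is expected to give 7% in this assay, with a range from 0% to 20%.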

Compound 4, a percentage reported as inhibition, at one concentration (the size of the read-out at that concentration, not a potency): 8%
The estimate for compound 4 lay 1 percentage points below the measured number; measured number inside the range.
By their numbers in this assay, from the lowest: compounds 1, 2, 4 and 3 (each within the scatter of the next).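

In this assay, fluoro in place of hydrogen on an aromatic carbon, para to a large group, gives a number 1 percentage points lower from compound 3 to compound 4 (within the scatter) and so adds no effect that can be told from the scatter. Going by these compounds alone, this is the first step read at this position, and both compounds remain near the floor of the read-out. No outside evidence bears on this result.

From the compounds shown here alone, whether an amine, a carboxylic acid or a longer chain at this place would move the number beyond the scatter remains open.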